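The compounds below may be only part of what the source reports. "The series", "measured", "known", "first", "only" and "open" are said of these compounds alone.

Measured so far in a toxicity assay on HeLa cells (Homo sapiens) for cytotoxicity; a higher number here means that more compound is tolerated, a lower number that less compound is tolerated (half-maximal cytotoxic concentration):

- compound 1 `COc1nc(-c2cccc(Cl)c2)ccc1[C@@H](c1ccccc1)[C@@](O)(CCN(C)C)c1cccc2ccccc12` gives "nd" (no result reported)
- compound 2 `COc1nc(-c2ccccc2F)ccc1[C@@H](c1ccccc1)[C@@](O)(CCN(C)C)c1cccc2ccccc12` gives "nd" (no result reported)
- compound 3 `COc1nc(-c2ccc(Cl)cc2)ccc1[C@@H](c1ccccc1)[C@@](O)(CCN(C)C)c1cccc2ccccc12` gives > 64 ug/mL

Compound 3 is the only one of the three with a reported result, and > 64 ug/mL is a limit of the assay, not a number. The whole reading of the series is thus (the limit of > 64 ug/mL in this assay, at which 1 of the 3 values shown sits), and compound 3 cannot be placed more exactly.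

Compound 4 `COc1nc(C2CCOCC2)ccc1[C@@H](c1ccccc1)[C@@](O)(CCN(C)C)c1cccc2ccccc12` has oxan-4-yl in place of 4-chlorophenyl on an aromatic carbon, next to the ring nitrogen (oxan-4-yl in place of 4-chlorophenyl on an aromatic carbon). Within the data shown here, no measured pair shows what a change of this kind does in this assay, so the expectation rests on compound 3 alone. The expected step of a number no higher from compound 3 to compound 4 (the limit leaves the size open) is none beyond the scatter, with no direction favoured. Compound 4 may well be reported only as a limit again. For compound 4 the estimated value is 64 ug/mL, with an expected range of 32 ug/mL to 128 ug/mL.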

Compound 4, half-maximal cytotoxic concentration: 22.5 ug/mL
Estimate against measurement, compound 4: 2.8-fold (0.45 log units) above, and the stated range ends above it.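

In this assay, this position on the shared core proves able to shift the read-out: oxan-4-yl in place of 4-chlorophenyl brings an at least 2.8-fold lower number from compound 3 to compound 4 (0.45 log units; beyond the scatter), so less compound is tolerated. Among these compounds, compound 4, at 22.5 ug/mL, gives the first actual number, and a non-aromatic ring with a ring oxygen at this place is what accompanies it. How large the step really is remains unknown, because the reading for compound 3 is only a limit: the limit of > 64 ug/mL in this assay, at which 1 of the 4 values shown sits.

The compounds shown leave open whether the lower number goes with the loss of the aromatic ring or with the ring oxygen. A cyclohexyl group, which has the non-aromatic ring without the oxygen, or a piperidin-4-yl group, which carries an amine nitrogen instead, would help to separate the two.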